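This account rests on a few compounds, and the source may have more. Where it says the series, first, only, none or still open, it means among the compounds named here.

Within the data shown here, in a functional assay on CCRF-CEM cells (Homo sapiens) for inhibition, read by MTT assay, with a stated time of 72 h (a lower number here means a stronger inhibitor, a higher number a weaker inhibitor), compound 3 `COc1ccc(-c2c(-c3cc(OC)c(OC)c(OC)c3)c(=O)c2=O)cc1[N+](=O)[O-]` gives 12200 nM, the highest number of the three measured so far. Compound 2 `COc1ccc(-c2c(-c3cc(OC)c(OC)c(OC)c3)c(=O)c2=O)cc1OC` gives 210 nM, and compound 1 `COc1cc(-c2c(-c3ccc4cc[nH]c4c3)c(=O)c2=O)cc(OC)c1OC` gives 6.6 nM, which makes compound 3 the weakest inhibitor of this small set. Compound 4 `COc1ccc(-c2c(-c3cc(OC)c(OC)c(OC)c3)c(=O)c2=O)cc1N` keeps the rest of compound 3 but carries amino in place of nitro on an aromatic carbon.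

Among the measured compounds shown here, only one measured step touches this same carbon: a 58-fold higher number from compound 2 to compound 3 (1.76 log units; beyond the scatter), with nitro in place of methoxy. That step was large, and it shows that the group on this carbon can matter greatly in this assay. For the measured compounds named here, no measured compound carries amino, so the size of the new step remains uncertain. Still, nitro leaves here, and compound 2, without nitro, stands at 210 nM, so a large move towards a lower number is expected. The expected step is a 35-fold lower number from compound 3 to compound 4 (1.54 log units; beyond the scatter). For compound 4 the estimated value is 350 nM, with an expected range from 60 nM to 2500 nM.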

Compound 4, half-maximal inhibitory concentration: 1.4 nM
The estimate for compound 4 lay 250-fold (2.40 log units) above the measured number, outside the stated range (below it).
By their numbers in this assay, from the lowest: compound 4; then compound 1; then compound 2; then compound 3.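

In this assay, among these compounds, this single carbon proves far more sensitive than the earlier compounds could show: amino in place of nitro gives an 8700-fold lower number from compound 3 to compound 4 (3.94 log units; beyond the scatter). Amino in place of methoxy on the same carbon also gives a large change, a 150-fold lower number from compound 2 to compound 4 (2.18 log units; beyond the scatter), so amino ranks ahead of both other groups tried here. With 3-amino-4-methoxyphenyl in place of 1H-indol-6-yl, the step is only modest but still beyond the scatter, a 4.7-fold lower number from compound 1 to compound 4 (0.67 log units; beyond the scatter), which places compound 4 ahead of the indole-bearing compound 1 as well.

Nothing measured here explains the size of these steps. The compounds shown also leave open whether a methylamino group, an acetamido group or a hydroxyl on this carbon would keep the strength seen with amino.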